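Triazole-linked flavanones: from propyl to 2-chlorobenzyl

The source may report more compounds than this note shows. Statements on the series, on what has been measured and on what is new or still open speak of the compounds shown alone.

Compound 1 `C#CCOc1cc(O)c2c(c1)O[C@H](c1ccc(OC)c(O)c1)CC2=O`: 20900 nM
Compound 2 `COc1ccc([C@@H]2CC(=O)c3c(O)cc(OCc4cn(Cc5ccccc5)nn4)cc3O2)cc1O`: 11000 nM
Compound 3 `CCCn1cc(COc2cc(O)c3c(c2)O[C@H](c2ccc(OC)c(O)c2)CC3=O)nn1`: 9670 nM

In a functional assay on RAW264.7 cells (Mus musculus) for inhibition, read by Griess assay, with stated times of 2 h and 24 h (on this read-out higher numbers stand for weaker inhibition and lower numbers for stronger inhibition), compound 3 gives the lowest number of the three, with compound 2 within the scatter of it and compound 1 further off, as the step of a 2.2-fold lower number from compound 1 to compound 3 (0.33 log units; beyond the scatter) shows. Compound 4 `COc1ccc([C@@H]2CC(=O)c3c(O)cc(OCc4cn(Cc5ccccc5Cl)nn4)cc3O2)cc1O` differs from compound 3 by 2-chlorophenyl in place of ethyl on a saturated chain carbon bound to an aromatic nitrogen. The step that bears on this change is a 1.1-fold lower number from compound 2 to compound 3 (0.06 log units; within the scatter), which exchanged ethyl for phenyl at the same place and stayed within the scatter. Compound 4 restores a phenyl carrying a chlorine at that place, so no step beyond the scatter is expected; compound 4 is estimated at 10500 nM (range 5000 nM to 22000 nM), meaning an expected step of a 1.1-fold higher number from compound 3 to compound 4 (0.04 log units; within the scatter).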

Compound 4, half-maximal inhibitory concentration: 6140 nM
For compound 4 the middle estimate is 1.7-fold (0.23 log units) above the measured one; the measured number falls inside the stated range.
By their numbers in this assay, from the lowest: compounds 4, 3, 2 and 1 (each within the scatter of the next, the first and the last beyond it).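

In this assay the exchange of ethyl for 2-chlorophenyl on a saturated chain carbon bound to an aromatic nitrogen gives a 1.6-fold lower number from compound 3 to compound 4 (0.20 log units; within the scatter) and chloro in place of hydrogen on an aromatic carbon gives a 1.8-fold lower number from compound 2 to compound 4 (0.25 log units; within the scatter) as its step. At this place, propyl, benzyl and 2-chlorobenzyl therefore all lie within the scatter of one another, even with a chlorine added to the ring. No measurement at hand gives a reason for this. Going by these compounds, whether an amine or a carboxylic acid at this place would carry the number beyond the scatter stays open, as does the effect of chloro on another carbon of that ring.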